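This account rests on a few compounds, and the source may have more. Where it says the series, first, only, none or still open, it means among the compounds named here.

Measured so far:
compound 1 `CCC(C)(C)Cc1c[nH]c(CCc2ccc(-c3csnn3)cc2)n1` — in a functional assay on HEK293 cells for agonist activity at Bombesin receptor subtype-3 (Homo sapiens), read by luminescence and calcium flux, with a stated time of 10 min (on this read-out lower numbers stand for an effect already at smaller amounts and higher numbers for an effect only at larger amounts of compound), compound 1 gives 538 nM
compound 2 `CCC(C)(C)Cc1c[nH]c(CCc2ccc(-c3cccnc3C(=O)O)cc2)n1` — in this assay compound 2 gives 1260 nM

Among the compounds with values here, compound 2 stands highest of the two numbers, with compound 1 the nearest point; the single step in the set is a 2.3-fold higher number from compound 1 to compound 2 (0.37 log units; beyond the scatter). Compound 3 `CCC(C)(C)Cc1c[nH]c(CCc2ccc(-c3ccns3)cc2)n1` differs from compound 2 by 1,2-thiazol-5-yl in place of 2-carboxypyridin-3-yl on an aromatic carbon. Within the data shown here, the group entering is a five-membered aromatic ring with two hetero atoms and no hydrogen-bond donor, which in its counted features comes close to the group carried by compound 1, so the step from compound 1 to compound 2 is the only one bearing on this change, read in reverse. A lower number for compound 3 is therefore expected, of about the size seen before, as a 2.1-fold lower number from compound 2 to compound 3 (0.32 log units; beyond the scatter). Compound 3 is estimated at 600 nM, with a range from 280 nM to 1300 nM; one step on a single pair carries little weight, and a result within the scatter of compound 2 cannot be excluded.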

Compound 3, half-maximal effective concentration: 63 nM
Beside the measured number, compound 3's estimate is 9.5-fold (0.98 log units) above it, and the stated range ends above it.
By their numbers in this assay, from the lowest: compound 3; then compound 1; then compound 2.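

Within the data shown here, the step of a 20-fold lower number from compound 2 to compound 3 (1.30 log units; beyond the scatter) in this assay is large, so this place, on an aromatic carbon para to a large group, responds far more strongly than the one earlier step suggested. The two five-membered aromatic rings also separate clearly, with 1,2-thiazol-5-yl in place of 1,2,3-thiadiazol-4-yl giving an 8.5-fold lower number from compound 1 to compound 3 (0.93 log units; beyond the scatter), so ring size alone does not set the number in this series. Nothing given here speaks to the origin of either step.

Open, on these data alone, is whether a carboxylic acid carried on the 1,2-thiazol-5-yl ring would keep the number of compound 3, and how a plain phenyl or an amine-bearing ring would compare at this place. As far as these compounds go, the rest of the core is the same in all three compounds, so the reach of this change in other settings also remains open.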